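This account rests on a few compounds, and the source may have more. Where it says the series, first, only, none or still open, it means among the compounds named here.

Measured so far:

Compound 1, `CC(C)c1ccc(Nc2ccc3c(OCCCN4CCN(C)CC4)cccc3n2)cc1`, gives 7760 nM in a functional assay on cells (Panel NCI-60 (60 carcinoma cell lines), Homo sapiens) for inhibition, read by sulforhodamine B assay, with a stated time of 48 h; a higher number here means a weaker inhibitor of growth, a lower number a stronger inhibitor of growth.
Compound 2, `CN1CCN(CCCOc2cccc3nc(Nc4ccc(F)c(F)c4)ccc23)CC1`, gives 2630 nM in this assay.

Compound 2 therefore holds the lowest of the two numbers, and its nearest neighbour is compound 1. Going by the values given here, the only step available, a 3.0-fold lower number from compound 1 to compound 2 (0.47 log units; beyond the scatter), came from exchanging one aryl group on the nitrogen attached to the shared core for another, and it was modest in size.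

Compound 3, `CN1CCN(CCCOc2cccc3nc(Nc4cc(Cl)cc(Cl)c4)ccc23)CC1`, has not yet been measured in this assay. It differs from compound 2 in the same place: 3,5-dichlorophenyl in place of 3,4-difluorophenyl on a nitrogen on an aromatic ring. Among the compounds with values here, the one measured step bears on this only loosely, since it swapped an isopropyl-bearing ring for a difluoro-bearing ring, whereas here one halogenated ring replaces another halogenated ring of the same size. Within the data shown here, nothing among the measured compounds points to a change beyond the scatter in either direction, so a step of roughly a 1.2-fold lower number from compound 2 to compound 3 (0.08 log units; within the scatter) is expected, which is to say essentially none. Compound 3 is accordingly estimated at 2200 nM, within a range from 700 nM to 7000 nM.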

Compound 3, concentration for 50% growth inhibition: 1770 nM
Compound 3: middle estimate off by 1.2-fold (0.09 log units), on the high side, within the range that was stated.
By their numbers in this assay, from the lowest: compounds 3 and 2 (each within the scatter of the next); then compound 1.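

In this assay the place on a nitrogen on an aromatic ring now carries a second halogenated ring, with a different halogen in a different arrangement: 3,5-dichlorophenyl in place of 3,4-difluorophenyl gives a 1.5-fold lower number from compound 2 to compound 3 (0.17 log units; within the scatter) and so leaves compound 2 and compound 3 indistinguishable in this assay. The 4-isopropylphenyl ring of compound 1 stays apart from both halogenated rings, and the new comparison gives a 4.4-fold lower number from compound 1 to compound 3 (0.64 log units; beyond the scatter) for the dichlorinated ring, which matches in direction what the difluorinated ring had already shown and remains modest in size. No measurement beyond these growth-inhibition numbers is available to explain either step.

The three compounds leave open whether halogens are needed on this ring at all, and an unsubstituted phenyl, a ring with a single chlorine, or a ring carrying a methoxy group or a nitrile would address that. They also leave open how much the rest of the molecule contributes, since the chain and the methylpiperazine are the same throughout, and a morpholine in place of the methylpiperazine or a shorter chain would test those parts.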